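The compounds below may be only part of what the source reports. "The series", "measured", "known", "first", "only" and "open" are said of these compounds alone.

Of the compounds shown here, two of one series have been measured in an assay on HL-60 cells for agonist activity at N-formyl peptide receptor 3 (Homo sapiens), read by calcium flux (a lower number here means that less compound is needed, a higher number that more compound is needed for the effect), and both sit at its limit. Compound 1 `COc1cccc(Cc2cc(-c3ccccc3)nn(CC(=O)Nc3ccc(Br)cc3)c2=O)c1` gives > 50000 nM in this assay, which is a limit of the assay rather than a number. Compound 2 `COc1ccc(Cc2cc(-c3ccc(Cl)cc3)nn(CC(=O)Nc3ccc(Br)cc3)c2=O)cc1` likewise gives > 50000 nM in this assay, again a limit. So compound 2 stands at the limit of > 50000 nM in this assay, at which 2 of the 2 values shown sit, with no measured number of its own and no measured step between compounds to lean on. Compound 3 `COc1ccc(Cc2cc(Cc3ccccc3)nn(CC(=O)Nc3ccc(Br)cc3)c2=O)cc1` differs from compound 2 by benzyl in place of 4-chlorophenyl on an aromatic carbon. With no step between measured compounds shown, the expectation for this assay is no change beyond the scatter. The expected step from compound 2 to compound 3 in this assay is a number no higher from compound 2 to compound 3 (the limit leaves the size open). Compound 3 is therefore expected to give about 50000 nM in this assay, within a range from 20000 nM to 150000 nM, and most likely to be reported again only as a limit.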

Compound 3, half-maximal effective concentration: > 50000 nM
Compound 3: only a limit was reported; the forecaster's own chance of this, stated with the estimate: 85%; the middle value lies on the limit itself.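

Among these compounds, compound 2 and compound 3 both stand only at a limit in this assay, so no step between them can be read. The three compounds shown share one position: the limit of > 50000 nM in this assay, at which 3 of the 3 values shown sit.

They leave open which change to the shared core, if any, would give a measured number in this assay.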